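The source may hold more compounds than are shown below. What is called first, only, known or untested is meant among the compounds shown, and "the series" means these compounds.

Measured in a functional assay on thoracic aorta (Rattus norvegicus, strain Wistar), with a stated time of 15 min; on this read-out lower numbers stand for an effect already at smaller amounts and higher numbers for an effect only at larger amounts of compound:
compound 1 `Cc1ccc(S(=O)(=O)N(C)C(=O)NC(C)c2cc(Br)ccc2OCc2ccccc2)cc1` gives 67100 nM
compound 2 `Cc1ccc(S(=O)(=O)N(C)C(=O)NC(C)c2cc(C)ccc2OCc2ccccc2)cc1` gives 181000 nM
compound 3 `CC(NC(=O)N(C)S(=O)(=O)c1ccccc1)c1ccccc1OCc1ccccc1` gives 21700 nM

Compound 3 has the lowest number of the three. The next compound, compound 4 `Cc1ccc(S(=O)(=O)N(C)C(=O)NC(C)c2ccccc2OCc2ccccc2)cc1`, carries methyl in place of hydrogen on an aromatic carbon, para to a large group (methyl in place of hydrogen on an aromatic carbon). Going by the values given here, the only measured step is methyl in place of bromo (a 2.7-fold higher number from compound 1 to compound 2 (0.43 log units; beyond the scatter)), which is a different exchange on a different carbon, so it is a loose guide. Compound 1 and compound 2 both carry the 4-methylphenyl group and have higher numbers than compound 3, but each also differs from it in a second place. A modest rise in this assay is therefore expected, with no firm size. The expected change is a 1.8-fold higher number from compound 3 to compound 4 (0.27 log units; within the scatter) and could stay within the scatter. For compound 4 the estimated value is 40000 nM (expected range 15000 nM to 110000 nM).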

Compound 4, half-maximal effective concentration: 31000 nM
For compound 4 the middle estimate is 1.3-fold (0.11 log units) above the measured one, within the range that was stated.
By their numbers in this assay, from the lowest: compounds 3 and 4 (each within the scatter of the next); then compound 1; then compound 2.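

In this assay, going from phenylsulfonyl to (4-methylphenyl)sulfonyl gives a 1.4-fold higher number from compound 3 to compound 4 (0.15 log units; within the scatter) and so, taken alone, this change does not separate the two compounds. With the 4-methylphenyl group held constant, the other substituted aromatic carbon can now be read alone: a 5.8-fold lower number from compound 2 to compound 4 (0.77 log units; beyond the scatter) for hydrogen in place of methyl and a 2.2-fold lower number from compound 1 to compound 4 (0.34 log units; beyond the scatter) for hydrogen in place of bromo. No data bearing on the cause of these steps are available.

Going by these compounds, whether a larger group on the phenylsulfonyl end, such as an amine or a methoxy group, would move the number remains open. On these data alone, the effect of bromo or methyl on the other aromatic carbon with an unsubstituted phenylsulfonyl group also remains open.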